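Series notes: positional isomer of the trifluoromethylphenyl group

The compounds below may be only part of what the source reports. "The series", "measured", "known", "first", "only" and "open" are said of these compounds alone.

Four compounds of one acylurea-hydrazone series are under review, all sharing the core shown in compound 3 `CN(C(=O)NC(=O)c1ccc(F)c(F)c1)c1nc(C(F)(F)F)c(C(=O)N/N=C/c2ccc(C(F)(F)F)cc2)s1`. Compound 1 `CN(C(=O)NC(=O)c1ccc([N+](=O)[O-])cc1)c1nc(C(F)(F)F)c(C(=O)N/N=C/c2cccc(C(F)(F)F)c2)s1` and compound 2 `CN(C(=O)NC(=O)c1ccc(F)c(F)c1)c1nc(C(F)(F)F)c(C(=O)N/N=C/c2ccc([N+](=O)[O-])cc2)s1` carry a nitro group on one of the outer aryl rings. In an ADME assay on L02 cells (Homo sapiens) for inhibition, read by MTT assay, with a stated time of 72 h (a higher number here means a weaker inhibitor, a lower number a stronger inhibitor), compound 1 is recorded as "not determined" (no result reported), and compound 2 likewise as "not determined" (no result reported), so neither supplies a number to compare against.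

Compound 3 therefore stands alone with a figure: in this assay compound 3 gives 13.2 ug/mL. With two of three entries lacking a result, compound 3 cannot be placed as stronger or weaker than anything else in the set; it is simply the only anchor.

Compound 4 `CN(C(=O)NC(=O)c1ccc(F)c(F)c1)c1nc(C(F)(F)F)c(C(=O)N/N=C/c2cccc(C(F)(F)F)c2)s1` has not been measured. Its difference from compound 3 is 3-(trifluoromethyl)phenyl in place of 4-(trifluoromethyl)phenyl on a carbon with a double bond to nitrogen. The atoms are the same; only the point of attachment of the trifluoromethyl group on that phenyl ring moves.

No measured pair in this set isolates such a change, so nothing shown indicates that a shift of this kind produces a step beyond the scatter. The expected step from compound 3 to compound 4 is therefore a 1.0-fold lower number from compound 3 to compound 4 (0.01 log units; within the scatter), that is, none beyond the usual spread. In this assay compound 4 is expected to give about 13 ug/mL, with a plausible range from 6 ug/mL to 28 ug/mL.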

Compound 4, half-maximal inhibitory concentration: 23.5 ug/mL
Estimate against measurement, compound 4: 1.8-fold (0.26 log units) below, and the stated range covers the measured number.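

Within the data shown here, compound 3 and compound 4 form the only pair that isolates a single change, here on a carbon with a double bond to nitrogen. In this assay, 3-(trifluoromethyl)phenyl in place of 4-(trifluoromethyl)phenyl amounts to a 1.8-fold higher number from compound 3 to compound 4 (0.25 log units; within the scatter), so this read-out does not separate the two positional isomers, and at this place the attachment point of the trifluoromethyl group has no effect that can be told from repeat measurements, on the strength of this one pair. Nothing available explains the reading or links it to any property of either group.

Among these compounds, compound 1 and compound 2 carry no result, so no steps involving them can be read, and the nitro-bearing members remain unplaced in this assay. Also open, going by these compounds, is whether an amine, a carboxylic acid or a longer chain in place of the trifluoromethyl group on that phenyl ring would give a step beyond the scatter, and whether the same isomer pair would read alike with the other outer aryl group found in compound 1.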